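Monkey plasma free fraction: amide methylation step

The source may hold more compounds than are shown below. What is called first, only, known or untested is meant among the compounds shown, and "the series" means these compounds.

Measured so far:
compound 1, `CCCCN(c1nc2c(C(=O)NC)cccc2o1)[C@H](C)c1ccc(-c2ccccc2-c2nnn[nH]2)cc1`: 0.000975
compound 2, `Cc1ccc(-c2nc(=O)o[nH]2)c(-c2ccc([C@@H](C)N(CC3CC3)c3nc4c(C(=O)O)cccc4o3)cc2)c1`: 0.00023
compound 3, `CCCCN(c1nc2c(C(=O)O)cccc2o1)[C@H](C)c1ccc(-c2cc(Cl)ccc2-c2nc(=O)o[nH]2)cc1`: 0.000135

The three compounds share a core and were run in an ADME assay on the whole organism (plasma, Macaca fascicularis) for protein binding, read by LC-MS, using equilibrium dialysis and cassette dosing, with a stated time of 24 h, at a dose of 1 mg/kg by the oral route; on this read-out lower numbers stand for a smaller free fraction and higher numbers for a larger free fraction. Compound 1 gives 0.000975 and stands highest of the three numbers. The nearer of the other two is compound 2 at 0.00023, the further is compound 3 at 0.000135; both gaps from compound 1 lie beyond the usual scatter. None of these pairs differs in a single place, so no isolated step can be read from the measured set.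

The next compound is compound 4, `CCCCN(c1nc2c(C(=O)N(C)C)cccc2o1)[C@H](C)c1ccc(-c2ccccc2-c2nnn[nH]2)cc1`. Relative to compound 1 the change is methyl in place of hydrogen on an amide-type nitrogen. Going by the values given here, no measured pair shows this change, and nothing in the set speaks for a large move in either direction. The expectation is therefore a step of no more than the scatter, if anything toward a slightly smaller free fraction, and the step from compound 1 to compound 4 is estimated as a 1.2-fold lower number from compound 1 to compound 4 (0.09 log units; within the scatter). For compound 4 in this assay the estimate is 0.0008, with a range from 0.0004 to 0.0016.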

Compound 4, unbound fraction: 0.00411
Compound 4: the middle estimate sits 5.1-fold (0.71 log units) below what was measured; measured number above the stated range.
By their numbers in this assay, from the lowest: compounds 3 and 2 (each within the scatter of the next); then compound 1; then compound 4.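

Methyl in place of hydrogen on this amide-type nitrogen gives a 4.2-fold higher number from compound 1 to compound 4 (0.62 log units; beyond the scatter) in this assay, so the change from methylcarbamoyl to dimethylcarbamoyl, only one carbon, moves the unbound fraction upward and by more than the usual scatter. Going by these compounds alone, this is the first step that can be read on its own, as the earlier compounds differ from one another in more than one place, and it shows that the read-out responds to what is carried on this nitrogen. No measurement in hand accounts for the direction or the size of this step.

Going by these compounds, the step rests on a single pair on the background of compound 1, so it remains open whether the same methyl would move the number in the same direction on another background. On these data alone, it is also open whether an ethyl group or a longer chain on this amide-type nitrogen would carry the unbound fraction further up, leave it where compound 4 stands, or bring it back down.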